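Series notes: ring-nitrogen substituent change on compound 3

The source may report more compounds than this note shows. Statements on the series, on what has been measured and on what is new or still open speak of the compounds shown alone.

Measured so far:
- compound 1 `O=C(NC1(c2ccc3c(n2)CCN3c2ccnc(C(F)(F)F)n2)CCC1)c1ccc(Cl)cc1`: 93 nM
- compound 2 `O=C(C1CC1)N1CCc2nc(C3(C(=O)Nc4ccc(F)cc4)CCC3)ccc21`: 8 nM
- compound 3 `O=C(OC1CC1)N1CCc2nc(C3(C(=O)Nc4ccc(F)cc4)CCC3)ccc21`: 2.7 nM

In an assay on HeLa cells for inhibition of Indoleamine 2,3-dioxygenase 1 (Homo sapiens) (on this read-out lower numbers stand for stronger inhibition and higher numbers for weaker inhibition), compound 3 gives the lowest of the three numbers; compound 2 sits nearest, compound 1 furthest. Among the measured compounds shown here, the one measured step with a single change is a 3.0-fold lower number from compound 2 to compound 3 (0.47 log units; beyond the scatter). Compound 4 `O=C(Nc1ccc(F)cc1)C1(c2ccc3c(n2)CCN3c2ccnc(C(F)(F)F)n2)CCC1` differs from compound 3 by 2-(trifluoromethyl)pyrimidin-4-yl in place of cyclopropyloxycarbonyl on a nitrogen on an aromatic ring in a ring. For the measured compounds named here, no measured step covers this change. Going by the values given here, compound 1 carries the same 2-(trifluoromethyl)pyrimidin-4-yl group but a different amide, so its value shows only that this group is compatible with measurable activity. The expectation for compound 4 is therefore a modest rise in number, step a 4.4-fold higher number from compound 3 to compound 4 (0.65 log units; beyond the scatter), with wide uncertainty. Compound 4 is estimated at 12 nM in this assay, range 3 nM to 50 nM.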

Compound 4, half-maximal inhibitory concentration: 127 nM
For compound 4 the middle estimate is 11-fold (1.02 log units) below the measured one; the measured number lies above the stated range.
By their numbers in this assay, from the lowest: compound 3; then compound 2; then compounds 1 and 4 (each within the scatter of the next).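

In this assay, replacing the carbonyl-linked groups on this nitrogen with 2-(trifluoromethyl)pyrimidin-4-yl gives a 47-fold higher number from compound 3 to compound 4 (1.67 log units; beyond the scatter) and a 16-fold higher number from compound 2 to compound 4 (1.20 log units; beyond the scatter), both larger than the change between the two carbonyl-linked groups, a 3.0-fold lower number from compound 2 to compound 3 (0.47 log units; beyond the scatter) on the same nitrogen. With the pyrimidine in place, exchanging ((4-chlorophenyl)carbonyl)amino for (4-fluorophenyl)carbamoyl on the saturated ring carbon gives a 1.4-fold higher number from compound 1 to compound 4 (0.14 log units; within the scatter), so this pair does not separate the two groups. No data shown account for the rise at the nitrogen.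

Still open, from the compounds shown here alone, is whether the rise follows the pyrimidine ring or its trifluoromethyl, which a pyrimidin-4-yl lacking trifluoromethyl would separate. Also open, going by these compounds, is how a plain methoxycarbonyl on this nitrogen compares with cyclopropyloxycarbonyl.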